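The source may report more compounds than this note shows. Statements on the series, on what has been measured and on what is new or still open speak of the compounds shown alone.

Measured so far:
compound 1, `C[C@H](NCc1ccc(OCCCCCN2CCN(c3cccc4c3ccn4S(=O)(=O)c3ccccc3)CC2)cc1)C(N)=O`: > 1000 nM
compound 2, `C#CCN(C)Cc1ccc(OCCCCN2CCN(c3cccc4c3ccn4Cc3cccc(Cl)c3)CC2)cc1`: 323 nM
compound 3, `C#CCN(C)Cc1ccc(OCCCCCCN2CCN(c3cccc4c3ccn4Cc3cccc(Cl)c3)CC2)cc1`: > 1000 nM

In an assay on BTI cells for inhibition of Amine oxidase [flavin-containing] B (Homo sapiens), read by fluorescence, with stated times of 30 min and 1 h (a higher number here means a weaker inhibitor, a lower number a stronger inhibitor), compound 1 gives only > 1000 nM, which is a limit of the assay and not a number. Compound 3 likewise gives > 1000 nM, again a limit. Among the compounds with values here, compound 2 gives 323 nM, the only value here that is a number; (the limit of > 1000 nM in this assay, at which 2 of the 3 values shown sit). Compound 4, `C#CCN(C)Cc1ccc(OCCCCCN2CCN(c3cccc4c3ccn4S(=O)(=O)c3ccccc3)CC2)cc1`, differs from compound 1 in one place: methyl(propargyl)amino in place of (1-carbamoylethyl)amino on a saturated chain carbon bound to an aromatic carbon. Within the data shown here, no measured pair shows this exact change, but compounds 2 and 3 already carry the entering group, and compound 2 gives 323 nM. On that basis a step toward stronger inhibition, beyond the scatter, is expected, with an at least 2.5-fold lower number from compound 1 to compound 4 (0.39 log units; beyond the scatter) as its expected size. Compound 4 is estimated at 400 nM, between 120 nM and 1300 nM.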

Compound 4, half-maximal inhibitory concentration: 154 nM
Beside the measured number, compound 4's estimate is 2.6-fold (0.41 log units) above it; measured number inside the range.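

In this assay, putting methyl(propargyl)amino in place of (1-carbamoylethyl)amino on a saturated chain carbon bound to an aromatic carbon gives an at least 6.4-fold lower number from compound 1 to compound 4 (0.81 log units; beyond the scatter). Within the data shown here, this is the first pair here that differs in one place, so the stronger inhibition can be tied to this change alone on this core. Compound 1 gives a limit and not a number, so the full size of the step stays unknown: the limit of > 1000 nM in this assay, at which 2 of the 4 values shown sit.

On these data alone, it remains open which part of the entering group matters, the propargyl or the methyl. A plain propargylamino or a dimethylamino group at this place could separate the two.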